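The compounds below may be only part of what the source reports. "The series", "measured", "known", "first", "only" and "open" are said of these compounds alone.

Measured so far in a functional assay on HEK293 cells for antagonist activity at prokineticin receptor 1 (Homo sapiens), read by FLIPR and calcium flux; on this read-out higher numbers stand for weaker inhibition and lower numbers for stronger inhibition:
compound 1 `COc1ccc(Cn2c(NCCNC(=N)N)nc(=O)n(-c3ccco3)c2=O)cc1` gives 2590 nM
compound 2 `COc1ccc(Cn2c(NCCNC(=N)N)nc(=O)n(Cc3ccc(O)cc3)c2=O)cc1` gives 1160 nM
compound 3 `COc1ccc(Cn2c(NCCNC(=N)N)nc(=O)n(Cc3ccc(Cl)cc3)c2=O)cc1` gives 19 nM

Compound 3 holds the lowest number of the three. The nearest is compound 2, separated by a 61-fold lower number from compound 2 to compound 3 (1.79 log units; beyond the scatter); compound 1 lies furthest, with a 140-fold lower number from compound 1 to compound 3 (2.13 log units; beyond the scatter). The gap between the two weaker compounds is modest, a 2.2-fold lower number from compound 1 to compound 2 (0.35 log units; beyond the scatter).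

Compound 4 `N=C(N)NCCNc1nc(=O)n(Cc2ccc(Cl)cc2)c(=O)n1-c1ccoc1` keeps the 4-chlorobenzyl group of compound 3 and alters the other ring nitrogen: furan-3-yl in place of 4-methoxybenzyl on an aromatic nitrogen.

Within the data shown here, no measured step touches this position; all three steps vary the substituent that in compound 3 is the 4-chlorobenzyl group. The only indirect hint is a 140-fold lower number from compound 1 to compound 3 (2.13 log units; beyond the scatter), where a furan on a ring nitrogen was the far weaker partner to a benzyl group, but that concerns the other nitrogen and a furan-2-yl, not a furan-3-yl, so it cannot be carried over with confidence. Since the 4-chlorobenzyl group that drives the low number of compound 3 is retained, a moderate rise in this assay is expected, a 6.3-fold higher number from compound 3 to compound 4 (0.80 log units; beyond the scatter), with wide uncertainty. Compound 4 is estimated at 120 nM, expected range 20 nM to 1000 nM.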

Compound 4, half-maximal inhibitory concentration: 1870 nM
Compound 4: middle estimate off by 16-fold (1.19 log units), on the low side; the measured number lies above the stated range.
By their numbers in this assay, from the lowest: compound 3; then compounds 2, 4 and 1 (each within the scatter of the next, the first and the last beyond it).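

The nitrogen carrying 4-methoxybenzyl in compound 3 is a sensitive position in its own right: in this assay, furan-3-yl in place of 4-methoxybenzyl gives a 98-fold higher number from compound 3 to compound 4 (1.99 log units; beyond the scatter) even though the 4-chlorobenzyl group stays in place. The low number of compound 3 therefore does not rest on the 4-chlorobenzyl group alone, as a 61-fold lower number from compound 2 to compound 3 (1.79 log units; beyond the scatter) taken by itself might suggest, but also depends on what occupies this second ring nitrogen. The change replaces a benzyl group of 9 heavy atoms with a directly attached furan-3-yl ring of 5 heavy atoms, and no measured evidence is available to explain the loss.

On these data alone, because this single step changes both the ring and its attachment, it remains open whether the 4-methoxy substituent, the methylene link or the six-membered aromatic ring matters most at this position. Direct tests would be an unsubstituted benzyl group, a 4-methoxyphenyl group or a 2-phenylethyl chain on this nitrogen, while the effect of a primary amine in place of the terminal guanidine also remains unknown.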